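The compounds below may be only part of what the source reports. "The series", "measured", "known", "first", "only" and "open" are said of these compounds alone.

Compound 1 `CC(=O)N1CCC(C(=O)N(CCCN2CCC(CNC(=O)c3cnccn3)CC2)c2ccc(C)c(Cl)c2)CC1` stands at the edge of what an ADME assay (Homo sapiens) for cytotoxicity (a lower number here means that less compound is tolerated, a higher number that more compound is tolerated), can report: its value > 52400 nM is a limit of the assay, not a number, and the evidence reads (the limit of > 52400 nM in this assay, at which 1 of the 2 values shown sits). Compound 2 `CC(=O)N1CCC(C(=O)N(CCCN2CCN(Cc3ccc(Cl)cc3)CC2)c2ccc(C)c(Cl)c2)CC1` gives 37600 nM in this assay. Compound 3 `CC(=O)N1CCC(C(=O)N(CCCN2CCC(CNC(=O)c3ccsc3)CC2)c2ccc(C)c(Cl)c2)CC1` differs from compound 1 by thiophen-3-yl in place of pyrazin-2-yl on a carbonyl carbon. Among the measured compounds shown here, no measured step matches this change, so the step of an at least 1.1-fold lower number from compound 1 to compound 3 (0.06 log units; that floor lies within the scatter) is expected to stay within the usual scatter, with no clear direction. Compound 3 is therefore estimated at 45000 nM in this assay, with a range from 20000 nM to 100000 nM.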

Compound 3, half-maximal cytotoxic concentration: > 51900 nM
Compound 3: no number, only a limit; the forecaster's own chance of this, stated with the estimate: 55%; middle value at least 1.1-fold (0.06 log units) away from the limit.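

Compound 3 gives > 51900 nM, a limit and not a number. Among the compounds shown here, compound 1 gives > 52400 nM, also a limit, and no step between compound 1 and compound 3 can be read. From the compounds shown here alone, whether thiophen-3-yl in place of pyrazin-2-yl on a carbonyl carbon shifts this assay at all remains open.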